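This account rests on a few compounds, and the source may have more. Where it says the series, first, only, none or still open, it means among the compounds named here.

The three measured compounds share one core and differ only on an aromatic carbon. Compound 1 `c1ccc(Cn2nnc3c(NC4CC4)nc(-c4ccccc4)nc32)cc1` is the unsubstituted member, and in an assay on Cerebral cortex for displacement of a labelled ligand from adenosine receptor A1 (Bos taurus) (on this read-out higher numbers stand for weaker inhibition and lower numbers for stronger inhibition), compound 1 gives 11.3 nM. Compound 2 `Clc1ccccc1Cn1nnc2c(NC3CC3)nc(-c3ccccc3)nc21` carries a chloro there, and in this assay compound 2 gives 11 nM. Compound 3 `Fc1ccccc1Cn1nnc2c(NC3CC3)nc(-c3ccccc3)nc21` carries a fluoro, and in this assay compound 3 gives 15 nM. The steps among them are all small: a 1.0-fold lower number from compound 1 to compound 2 (0.01 log units; within the scatter), a 1.3-fold higher number from compound 1 to compound 3 (0.12 log units; within the scatter) and a 1.4-fold higher number from compound 2 to compound 3 (0.13 log units; within the scatter). Compound 2 therefore has the lowest of the three numbers, yet it sits within the scatter of both compound 1 and compound 3, so no ranking among them can be stated.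

Compound 4 `OCCCNc1nc(-c2ccccc2)nc2c1nnn2Cc1ccccc1Cl` has not been measured. It differs from compound 2 in a single place: 3-hydroxypropyl in place of cyclopropyl on a nitrogen on an aromatic ring. For the measured compounds named here, none of the measured steps touches this nitrogen; all three change a substituent on an aromatic carbon and all stayed within the scatter. The data thus hold no direct guide for this step in this assay, and the expectation rests on the change itself. For compound 4 the number is estimated at 40 nM, with a range from 10 nM to 160 nM. The expected step, a 3.6-fold higher number from compound 2 to compound 4 (0.56 log units; beyond the scatter), is toward a higher number, but with broad uncertainty.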

Compound 4, inhibition constant: 33 nM
For compound 4 the middle estimate is 1.2-fold (0.08 log units) above the measured one, within the range that was stated.
By their numbers in this assay, from the lowest: compounds 2, 1 and 3 (each within the scatter of the next); then compound 4.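

For the compounds shown here, putting 3-hydroxypropyl in place of cyclopropyl on this nitrogen gives the only step that lies beyond the scatter: in this assay the change yields a 3.0-fold higher number from compound 2 to compound 4 (0.48 log units; beyond the scatter). The earlier steps, all on an aromatic carbon, stayed within the scatter, so this nitrogen is the one place shown where a change moves the number, and the move is modest, with compound 4 still giving 33 nM in the same read-out. Nothing at hand accounts for the size or direction of this step.

The single step swaps a three-membered carbon ring for an open chain and also adds a hydroxyl, so the compounds shown do not separate these two changes: plain propyl on the same nitrogen would be needed to tell them apart. They also leave open how the length and the end of the chain count, as seen with 2-hydroxyethyl, 4-hydroxybutyl or a propyl chain ending in an amine or a carboxylic acid, and whether the step holds with fluoro or hydrogen in place of the chloro of compound 2.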